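The source may hold more compounds than are shown below. What is called first, only, known or untested is meant among the compounds shown, and "the series" means these compounds.

Measured compounds:
Compound 1, `O=C(NCCCN1CCN(c2ccccn2)CC1)c1cc(Cl)cc(Cl)c1`: > 10000 nM
Compound 2, `O=C(NCCCN1CCN(c2ncccn2)CC1)c1cc(Cl)cc(Cl)c1`: > 10000 nM
Compound 3, `O=C(NCCCN1CCN(c2ccccn2)CC1)c1cccc2ccccc12`: > 10000 nM

In an assay on HEK293 cells for inhibition of sodium-dependent dopamine transporter (Homo sapiens), read by scintillation counting (on this read-out higher numbers stand for weaker inhibition and lower numbers for stronger inhibition), compound 1 gives > 10000 nM, which is a limit of the assay and not a number. In the same assay compound 2 gives > 10000 nM, again a limit. Compound 3 gives > 10000 nM, also a limit. All three values therefore sit at the limit of > 10000 nM in this assay, at which 3 of the 3 values shown sit, and nothing separates them. Going by the values given here, the one step between compounds that differ in a single place, the step that the two limits leave unreadable from compound 1 to compound 2, is left unreadable by the two limits.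

Compound 4, `O=C(NCCCN1CCN(c2cccc(Cl)c2Cl)CC1)c1cccc2ccccc12`, has not yet been measured. It differs from compound 3 in one place: 2,3-dichlorophenyl in place of pyridin-2-yl on an amine nitrogen in a ring. Among the compounds with values here, no measured step bears on this change; the only step available is unreadable, and the two compounds that share the naphthalene amide of compound 3 and compound 4 carry nothing but limits. From the compounds shown here alone, there is thus no measured ground to expect a step of any size or direction beyond the scatter, and it is equally open whether compound 4 will again return only a limit.

Compound 4 is expected to give about 8000 nM, with a range from 1500 nM to 40000 nM, the expected step from compound 3 being an at least 1.2-fold lower number from compound 3 to compound 4 (0.09 log units; that floor lies within the scatter).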

Compound 4, half-maximal inhibitory concentration: > 10000 nM
Compound 4: a limit, no number; the forecaster's own chance of this, stated with the estimate: 55%; middle value at least 1.2-fold (0.09 log units) away from the limit.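

In this assay compound 4 gives > 10000 nM, a limit of the assay and not a number. Going by these compounds alone, the step from compound 3 to compound 4 therefore cannot be read, and no new step results. The compounds shown leave open how strongly any of them inhibits in this assay, and whether the group on the amine nitrogen in the ring changes that, with every value at one limit: the limit of > 10000 nM in this assay, at which 4 of the 4 values shown sit.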